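Estimating a chain change from compound 1

The compounds below may be only part of what the source reports. "The series", "measured", "known", "first", "only" and "open" are said of these compounds alone.

Going by the values given here, in an ADME assay on MT4 cells (Homo sapiens) for cytotoxicity, read by MTT assay (on this read-out higher numbers stand for lower toxicity in this test and lower numbers for higher toxicity in this test), compound 1 (`O=C1c2ccccc2C(=O)N1CCOC(=S)N(C(=O)c1cccc([N+](=O)[O-])c1)c1ccc(Cl)cc1`) gives 18000 nM as the lower of the two numbers so far, and compound 2 (`O=C1c2ccccc2C(=O)N1CCOC(=S)N(C(=O)c1ccc2ccccc2c1)c1ccc(Cl)cc1`) gives 37000 nM as the higher. Compound 3 (`O=C1c2ccccc2C(=O)N1CCCOC(=S)N(C(=O)c1cccc([N+](=O)[O-])c1)c1ccc(Cl)cc1`) has not yet been measured. Among the compounds with values here, its one difference from compound 1 is a group of 12 heavy atoms (9 carbon, 1 nitrogen, 2 oxygen; one five-membered non-aromatic ring with 1 hetero atom, one six-membered aromatic ring of carbon only) in place of a group of 11 heavy atoms (8 carbon, 1 nitrogen, 2 oxygen; one five-membered non-aromatic ring with 1 hetero atom, one six-membered aromatic ring of carbon only), on a saturated chain carbon, two bonds along the chain from an oxygen on an unsaturated carbon while the rest of the molecule stays the same. Within the data shown here, the only measured step is a 2.1-fold higher number from compound 1 to compound 2 (0.31 log units; beyond the scatter) with naphthalen-2-yl in place of 3-nitrophenyl on a carbonyl carbon. That step is modest and sits at another place in the molecule, so it offers a rough sense of size but no direction for this change. The expected move in this assay is therefore small, an estimated 1.1-fold higher number from compound 1 to compound 3 (0.05 log units; within the scatter) with its direction uncertain. For compound 3 the estimated value is 20000 nM (expected range 9000 nM to 45000 nM).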

Compound 3, half-maximal cytotoxic concentration: 53000 nM
Estimate against measurement, compound 3: 2.7-fold (0.42 log units) below; measured number outside the range, above it.
By their numbers in this assay, from the lowest: compound 1; then compounds 2 and 3 (each within the scatter of the next).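

In this assay, the group of 12 heavy atoms in place of the group of 11 heavy atoms gives a 2.9-fold higher number from compound 1 to compound 3 (0.47 log units; beyond the scatter) and so moves the number beyond the scatter. This shows that the place on a saturated chain carbon, two bonds along the chain from an oxygen on an unsaturated carbon, also affects the result, even though both groups have the same rings, hydrogen-bond counts and lack of net charge. The direction is towards lower toxicity in this test, but nothing measured here explains the shift.

A longer chain could show whether the number keeps rising or turns back down. As far as these compounds go, it also remains open whether the same chain change would act alike with naphthalen-2-yl on the carbonyl carbon, or whether an amine in the chain would be tolerated.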